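Swapping a Methylcyclohexyl Amide for a Fluoropiperidine Urea

The source may hold more compounds than are shown below. What is called first, only, known or untested is meant among the compounds shown, and "the series" means these compounds.

Measured compounds:
compound 1, `O=C(c1ccc(Cl)cc1)N1CC(c2nc(-c3cccc(F)c3)no2)C1`: 2500 nM
compound 2, `CC1CCCC(C(=O)N2CC(c3nc(-c4cccc(Cl)c4)no3)C2)C1`: 410 nM

Of the compounds shown here, two have so far been measured in an assay on HEK293 cells for positive allosteric modulation of metabotropic glutamate receptor 5 (Homo sapiens), read by FLIPR; a higher number here means that more compound is needed for the effect, a lower number that less compound is needed. Compound 1 has the structure `O=C(c1ccc(Cl)cc1)N1CC(c2nc(-c3cccc(F)c3)no2)C1` and in this assay compound 1 gives 2500 nM. Compound 2, with the structure `CC1CCCC(C(=O)N2CC(c3nc(-c4cccc(Cl)c4)no3)C2)C1`, gives in this assay a value of 410 nM. For the measured compounds named here, of the two numbers, the one for compound 2 is the lower, and the gap to compound 1 is larger than the usual scatter of repeated measurements, so compound 2 is the stronger of the pair on these data. The two compounds differ in more than one place, so no single step can be read from them.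

Compound 3, with the structure `O=C(N1CCC(F)CC1)N1CC(c2nc(-c3cccc(Cl)c3)no2)C1`, has not yet been measured in this assay. It is derived from compound 2 by a single change: 4-fluoropiperidin-1-yl in place of 3-methylcyclohexyl on a carbonyl carbon. The carbonyl carbon thus carries a ring nitrogen instead of a ring carbon on its far side.

Going by the values given here, no measured pair shows such a change, so the expectation for compound 3 rests on compound 2 alone and on the size of this change. A modest loss is expected, of a size close to the scatter, as the step of a 2.0-fold higher number from compound 2 to compound 3 (0.29 log units; within the scatter). Compound 3 is therefore estimated at 800 nM in this assay, with a plausible range from 250 nM to 3000 nM.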

Compound 3, half-maximal effective concentration: 990 nM
Compound 3: the middle estimate sits 1.2-fold (0.09 log units) below what was measured; the measured number falls inside the stated range.
By their numbers in this assay, from the lowest: compound 2; then compound 3; then compound 1.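

For the compounds shown here, the step from 3-methylcyclohexyl to 4-fluoropiperidin-1-yl on the carbonyl carbon is the first change that can be read in one place, and in this assay it is a 2.4-fold higher number from compound 2 to compound 3 (0.38 log units; beyond the scatter). The two groups have the same count of heavy atoms, and each is a six-membered non-aromatic ring, yet the swap turns the amide into a urea at a modest but real cost, so this position accepts a ring joined through nitrogen and still gives a measurable effect, though it does not do so for free. No measurement shown here accounts for the size of this step.

Going by these compounds alone, the swap changes several things at once: the ring atom bound to the carbonyl carbon, the added fluorine and the lost methyl group, so the single step cannot assign the loss to any one of them. Unsubstituted piperidin-1-yl would separate the ring nitrogen from the fluorine, and morpholine or an open-chain group such as diethylamino would show how far this position can move from a carbon-only ring.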